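A few compounds are considered here, and "the series" means these few. Any claim that something is new, unique, unknown or untested is made for them only; others in the source may bear on it.

For the measured compounds named here, the three measured members of this set share one core: compound 1 `COC(=O)c1ccc(NCc2cncn2Cc2ccc(N)cc2)cc1-c1ccccc1`, compound 2 `COC(=O)c1ccc(NCc2cncn2Cc2ccc(F)cc2)cc1-c1ccccc1` and compound 3 `COC(=O)c1ccc(NCc2cncn2Cc2ccc(C(C)(C)C)cc2)cc1-c1ccccc1`. In a toxicity assay on NIH3T3 cells (Mus musculus) for cytotoxicity, read by resazurin assay (on this read-out lower numbers stand for an effect already at smaller amounts and higher numbers for an effect only at larger amounts of compound), compound 1 gives a limit rather than a number, > 10000 nM. For compound 2 the entry in this assay reads "not determined" (no result reported). Compound 3 has no number either in this assay, its entry reading "not determined" (no result reported), so it stands beside one further empty entry and one compound with a mark on the scale. That one mark comes from compound 1 alone, (the limit of > 10000 nM in this assay, at which 1 of the 3 values shown sits). Compound 4 `COC(=O)c1ccc(NCc2cncn2Cc2ccc(C)cc2)cc1-c1ccccc1` differs from compound 3 by methyl in place of tert-butyl on an aromatic carbon. Going by the values given here, with no step measured between any two compounds, no shift beyond the usual scatter in this assay is expected from this change. Compound 4 is therefore estimated at about 10000 nM in this assay, within 3000 nM to 30000 nM, most likely reported again as a limit.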

Compound 4, half-maximal effective concentration: 50000 nM
The estimate for compound 4 lay 5.0-fold (0.70 log units) below the measured number, and the stated range ends below it.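

No step from compound 1 to compound 4 can be read in this assay, because compound 1 carries only a limit: the limit of > 10000 nM in this assay, at which 1 of the 4 values shown sits.

The compounds shown leave open how far methyl in place of amino on an aromatic carbon shifts the value in this assay.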